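The source may hold more compounds than are shown below. What is called first, only, known or untested is meant among the compounds shown, and "the series" means these compounds.

Measured so far in a functional assay on KB cells (Homo sapiens) for inhibition; a lower number here means a stronger inhibitor, a higher number a weaker inhibitor:
compound 1 `CCCCOC[C@H]1OC(n2c(Cl)nc3cc(Cl)c(Cl)cc32)[C@H](O)[C@@H]1O`: 60000 nM
compound 2 `O[C@@H]1[C@@H](CCl)OC(n2c(Cl)nc3cc(Cl)c(Cl)cc32)[C@@H]1O`: 90000 nM
compound 3 `O[C@@H]1[C@@H](CBr)OC(n2c(Cl)nc3cc(Cl)c(Cl)cc32)[C@@H]1O`: 90000 nM

The three compounds share one core and differ only in the group on a saturated chain carbon bound to a saturated ring carbon. In this assay, compound 3 stands level with compound 2, and the comparison gives no change at the digits printed from compound 2 to compound 3 (within the scatter). Set against the butoxy compound, it shows a 1.5-fold higher number from compound 1 to compound 3 (0.18 log units; within the scatter). The chloro compound behaves alike, with a 1.5-fold higher number from compound 1 to compound 2 (0.18 log units; within the scatter). Butoxy, chloro and bromo at this place have therefore not moved the number beyond the scatter.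

The next compound, compound 4 `CSC[C@H]1OC(n2c(Cl)nc3cc(Cl)c(Cl)cc32)[C@H](O)[C@@H]1O`, carries methylsulfanyl in place of bromo on a saturated chain carbon bound to a saturated ring carbon. Among the measured compounds shown here, no measured step involves methylsulfanyl itself, so the only evidence is the three steps at the same place, and all of them stay within the scatter. On that evidence, no step beyond the scatter is expected in this assay, in either direction. The expected step is a 1.1-fold lower number from compound 3 to compound 4 (0.05 log units; within the scatter). For compound 4 the estimated value is 80000 nM, with an expected range from 35000 nM to 180000 nM.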

Compound 4, half-maximal inhibitory concentration: > 100000 nM
Compound 4 was reported as a limit (the forecaster's own chance of this, stated with the estimate: 20%); middle value at least 1.2-fold (0.09 log units) from the limit.
By their numbers in this assay, from the lowest: compounds 1, 2 and 3 (each within the scatter of the next). At a limit, above all of these: compound 4.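

In this assay compound 4 gives > 100000 nM, which is a limit and not a number. Read as floors, the steps are an at least 1.1-fold higher number from compound 3 to compound 4 (0.04 log units; that floor lies within the scatter), an at least 1.1-fold higher number from compound 2 to compound 4 (0.04 log units; that floor lies within the scatter) and an at least 1.6-fold higher number from compound 1 to compound 4 (0.22 log units; that floor lies within the scatter), so even the change from butoxy, which gives the widest floor, does not show that methylsulfanyl moves the number beyond the scatter, and the true size of each step remains unknown. What this adds to the earlier compounds is that a group on this saturated chain carbon bound to a saturated ring carbon now reaches the limit of the assay, and a step at this place can then be given only as a floor: the limit of > 100000 nM in this assay, at which 1 of the 4 values shown sits.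

The compounds shown leave open how far the value of compound 4 lies from that limit, and whether any group at this place can move the number beyond the scatter in either direction. On these data alone, how an amine, a carboxylic acid or a chain longer than butoxy would read at this place in this assay also stays open.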